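The compounds below may be only part of what the source reports. "The series", "measured", "known", "first", "only" and "open" are said of these compounds alone.

Measured so far in a functional assay on DU-145 cells (Homo sapiens) for inhibition, read by trypan blue exclusion, with a stated time of 96 h; on this read-out lower numbers stand for stronger inhibition of growth and higher numbers for weaker inhibition of growth:
- Compound 1 `O=C(/C(=C\c1c[nH]c2ccc(Cl)cc12)SCc1ccc(F)cc1)c1ccc(Br)cc1`: 1000 nM
- Compound 2 `Cc1ccc(S(=O)(=O)/C(=C/c2c[nH]c3ccc(Cl)cc23)C(=O)c2ccc(Br)cc2)cc1`: 10000 nM

Compound 1 holds the lower number of the two, so it inhibits growth more strongly. Compound 3 `Cc1ccc(C)c(/C=C(/SCc2ccc(F)cc2)C(=O)c2ccc(Br)cc2)c1` differs from it in one group: 2,5-dimethylphenyl in place of 5-chloro-1H-indol-3-yl on a double-bonded chain carbon bound to a double-bonded chain carbon. Here, 2,5-dimethylphenyl replaces 5-chloro-1H-indol-3-yl on a double-bonded chain carbon bound to a double-bonded chain carbon. For the measured compounds named here, the only measured step, a 10-fold higher number from compound 1 to compound 2 (1.00 log units; beyond the scatter), changes a different group, so it offers only a rough guide to size. Going by the values given here, no measurement yet tests this exchange directly. The expected step, a 3.0-fold higher number from compound 1 to compound 3 (0.48 log units; beyond the scatter), is smaller and equally upward, but uncertain. Compound 3 is estimated at 3000 nM, within a range of 600 nM to 15000 nM.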

Compound 3, concentration for 50% growth inhibition: 1000 nM
Compound 3: the middle estimate sits 3.0-fold (0.48 log units) above what was measured; low and high end bracket the measured number.
By their numbers in this assay, from the lowest: compounds 1 and 3 (each within the scatter of the next); then compound 2.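

In this assay, placing 2,5-dimethylphenyl where 5-chloro-1H-indol-3-yl stood gives no change at the digits printed from compound 1 to compound 3 (within the scatter). With the (4-fluorobenzyl)sulfanyl group kept, this place therefore tolerates the loss of the five-membered ring, its hydrogen-bond donor and the chlorine, and a single carbon-only aromatic ring serves as well. No supporting data explain why the two groups match. Going by these compounds, it remains open whether an unsubstituted phenyl, or a phenyl ring carrying an amine or a carboxylic acid, would fit this place equally well. The same exchange on the (4-methylphenyl)sulfonyl compound 2 is also an open question.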